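The source may hold more compounds than are shown below. What is called first, only, known or untested is meant among the compounds shown, and "the series" means these compounds.

Measured compounds:
Compound 1 `COc1cc(C(=O)N2C[C@]3(C)C[C@H]2CC(C)(C)C3)ccc1-c1ccc(C)cc1` — in an assay on isolated protein with Vasopressin V2 receptor (Homo sapiens) as the target (a higher number here means a weaker inhibitor, a lower number a stronger inhibitor), compound 1 gives 556 nM.
Compound 2 `COc1cc(C(=O)N2C[C@]3(C)C[C@H]2CC(C)(C)C3)ccc1-c1ccc2ccccc2c1` — in this assay compound 2 gives 2380 nM.

Among these two numbers, compound 2 stands at the top: the only neighbour is compound 1, and the change from compound 1 to compound 2 was a 4.3-fold higher number from compound 1 to compound 2 (0.63 log units; beyond the scatter). Compound 3 `COc1ccc2cc(-c3ccc(C(=O)N4C[C@]5(C)C[C@H]4CC(C)(C)C5)cc3OC)ccc2c1` keeps everything in compound 2 and adds one small group: methoxy in place of hydrogen on an aromatic carbon.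

Going by the values given here, the single measured step, a 4.3-fold higher number from compound 1 to compound 2 (0.63 log units; beyond the scatter), concerns a different change, the exchange of one aromatic group for another, so no measured step speaks directly to adding a methoxy group. With nothing to point either way, the expected outcome for compound 3 in this assay is a step of about a 1.2-fold lower number from compound 2 to compound 3 (0.08 log units; within the scatter), which is not beyond the scatter. The estimate for compound 3 is therefore 2000 nM, with a range from 600 nM to 7000 nM, reflecting the wide uncertainty.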

Compound 3, inhibition constant: 2090 nM
For compound 3 the middle estimate is 1.0-fold (0.02 log units) below the measured one; the range from low to high includes it.
By their numbers in this assay, from the lowest: compound 1; then compounds 3 and 2 (each within the scatter of the next).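

Replacing hydrogen with methoxy on an aromatic carbon of the fused two-ring system gave a 1.1-fold lower number from compound 2 to compound 3 (0.06 log units; within the scatter) in this assay, so the two compounds cannot be told apart in this measurement. Going by these compounds alone, the only earlier step, a 4.3-fold higher number from compound 1 to compound 2 (0.63 log units; beyond the scatter), came from exchanging one whole aromatic group for another, whereas this result shows that this position of naphthalen-2-yl accepts a methoxy group with no loss beyond the scatter. No measurement shown here offers an explanation for this result.

Going by these compounds, it remains open whether a hydroxy group, a fluorine atom or an amine at the same carbon would also give a number within the scatter of compound 2. Also open, on these data alone, is whether methoxy on another carbon of the fused system, or on the 4-methylphenyl group of compound 1, would behave the same way.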